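Carbamate-to-amide swap in a pyrrolidine dopamine transporter series

The source may report more compounds than this note shows. Statements on the series, on what has been measured and on what is new or still open speak of the compounds shown alone.

Measured so far:
compound 1, `CCOC(=O)N(Cc1ccccc1C(C)C)[C@H]1CCNC1`, 3340 nM
compound 2, `CCOC(=O)N(Cc1ccccc1SC)[C@H]1CCNC1`, "not determined" (no result reported)

Compound 1 stands alone on the numbers shown: in an assay on HEK293 cells for inhibition of sodium-dependent dopamine transporter (Homo sapiens) (on this read-out higher numbers stand for weaker inhibition and lower numbers for stronger inhibition), compound 1 gives 3340 nM, and compound 2 gives only "not determined" (no result reported), so nothing can be said of a trend. Compound 3 is `CC(C)C(=O)N(Cc1ccccc1C(C)C)[C@H]1CCNC1`. It differs from compound 1 by isopropyl in place of ethoxy on a carbonyl carbon. Within the data shown here, no step between measured compounds is available to calibrate this change. Compound 3 is therefore expected to sit close to compound 1, with a step of a 1.1-fold lower number from compound 1 to compound 3 (0.05 log units; within the scatter) that is not expected to exceed the scatter. The estimate for compound 3 is 3000 nM, within 1000 nM to 9000 nM.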

Compound 3, inhibition constant: 3410 nM
Compound 3: middle estimate off by 1.1-fold (0.06 log units), on the low side; low and high end bracket the measured number.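

In this assay, among these compounds, the swap of ethoxy for isopropyl on a carbonyl carbon gives a 1.0-fold higher number from compound 1 to compound 3 (0.01 log units; within the scatter) and so provides the first calibrated step at this position. Losing the ethoxy oxygen, with its hydrogen-bond acceptor, leaves the read-out within the scatter, so this position accepts carbamate and amide alike in this pair. No independent data bear on this result.

Going by these compounds, whether an amine or a longer chain on this carbonyl carbon would hold the same level remains open. Whether the swap behaves alike on the core of compound 2 also stays unresolved, since that compound has no number.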